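Chain shortening on two pyridazinone-type cores: notes

A few compounds are considered here, and "the series" means these few. Any claim that something is new, unique, unknown or untested is made for them only; others in the source may bear on it.

Measured compounds:
- compound 1, `N=C(S)CCCn1nc(-c2ccccc2)ccc1=O`: 31.9 mg/kg
- compound 2, `N=C(S)CCCCCCN1N=C(c2ccccc2)CCC1=O`: 58.8 mg/kg
- compound 3, `N=C(S)CCCCCn1nc(-c2ccccc2)ccc1=O`: 23.3 mg/kg

All three numbers come from a functional assay on the whole organism (stomach) with Rattus norvegicus as the target; on this read-out higher numbers stand for an effect only at larger amounts of compound and lower numbers for an effect already at smaller amounts. Compound 3 carries the longer chain; compound 1 differs from it by a group of 3 heavy atoms (1 carbon, 1 nitrogen, 1 sulfur; no ring) in place of a group of 5 heavy atoms (3 carbon, 1 nitrogen, 1 sulfur; no ring), on a saturated chain carbon, three bonds along the chain from an aromatic nitrogen, and that step, a 1.4-fold higher number from compound 3 to compound 1 (0.14 log units; within the scatter), stays within the scatter. Compound 2 sits on a different core; the difference between the core of compound 2 and the core of compound 3 is not broken down here. Among the three, compound 2 gives the highest number, and its gap to compound 3 lies beyond the scatter, while its gap to compound 1 does not.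

Compound 4, `N=C(S)CCCCN1N=C(c2ccccc2)CCC1=O`, is not yet measured. It differs from compound 2 by a group of 3 heavy atoms (1 carbon, 1 nitrogen, 1 sulfur; no ring) in place of a group of 5 heavy atoms (3 carbon, 1 nitrogen, 1 sulfur; no ring), on a saturated chain carbon, four bonds along the chain from an amide-type nitrogen in a ring. Within the data shown here, this is the same kind of change as the one from compound 3 to compound 1, though the place differs: there the group sits three bonds along the chain from an aromatic nitrogen, here four bonds along the chain from an amide-type nitrogen in a ring. Because a 1.4-fold higher number from compound 3 to compound 1 (0.14 log units; within the scatter) stayed within the scatter, a small step is expected again, a 1.3-fold higher number from compound 2 to compound 4 (0.11 log units; within the scatter). Compound 4 is therefore estimated at 75 mg/kg in this assay, with a likely range from 35 mg/kg to 160 mg/kg.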

Compound 4, dose for half-maximal effect: 100 mg/kg
The estimate for compound 4 lay 1.3-fold (0.12 log units) below the measured number, and the stated range covers the measured number.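

In this assay, the group of 3 heavy atoms in place of the group of 5 heavy atoms on the second core gives a 1.7-fold higher number from compound 2 to compound 4 (0.23 log units; within the scatter), and the two steps on the two cores cannot be told apart: the same change on two cores in this assay, a 1.4-fold higher number (0.14 log units; within the scatter) from compound 3 to compound 1 and a 1.7-fold higher number (0.23 log units; within the scatter) from compound 2 to compound 4, 1.2-fold (0.09 log units) apart, within the scatter of two such steps
Across these two pairs, the change therefore carries from one core to the other without a detectable difference in step size, and neither step taken alone lies beyond the scatter. This does not show that the change has a real effect on either core, and two pairs, with the group at a different place on the chain in each, do not establish that it would carry to any further core.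

No pair shown has the two cores at the same chain length, so the cores themselves cannot be compared directly. As far as these compounds go, it also remains open how an amine or a carboxylic acid would read in place of the groups exchanged here, on either core.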